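This account rests on a few compounds, and the source may have more. Where it says the series, first, only, none or still open, it means among the compounds named here.

Compound 2, with the structure `CC(C)=CCC1Cc2c(OC(=O)Nc3ccccc3F)cc(=O)n(CCCO)c2CC1(C)C`, was measured in a functional assay on PANC-1 cells (Homo sapiens) for inhibition, read by MTT assay, with a stated time of 24 h, tested at 10 uM (on this read-out higher numbers stand for more inhibition at the one concentration tested (going by the name of the read-out) and lower numbers for less inhibition), and gave 0%. Its nearest measured neighbour is compound 1, with the structure `COc1ccccc1NC(=O)Oc1cc(=O)n(CCCO)c2c1CC(CC=C(C)C)C(C)(C)C2`, which in this assay gave 0%. Going by the values given here, the one step between them, no change at the digits printed from compound 1 to compound 2 (within the scatter), therefore leaves compound 2 level with compound 1 on this read-out, with neither compound showing any measurable inhibition.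

The next compound, compound 3, has the structure `CC(C)=CCC1Cc2c(OC(=O)Nc3ccc(F)cc3F)cc(=O)n(CCCO)c2CC1(C)C`. It differs from compound 2 by fluoro in place of hydrogen on an aromatic carbon, so the 2-fluorophenyl becomes a 2,4-difluorophenyl.

Among the compounds with values here, only one measured step bears on this change: the exchange of methoxy for fluoro on the same aromatic ring, which produced no change at the digits printed from compound 1 to compound 2 (within the scatter). Adding a second fluoro to that ring is expected to behave the same way, so the estimated step of a number 2 percentage points higher from compound 2 to compound 3 (within the scatter) stays within the scatter. Compound 3 is therefore expected to give 2%, within a range from 0% to 15%.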

Compound 3, a percentage reported as inhibition, at one concentration (the size of the read-out at that concentration, not a potency): 0%
Beside the measured number, compound 3's estimate is 2 percentage points above it; the range from low to high includes it.
By their numbers in this assay, from the lowest: compounds 1, 2 and 3 (each within the scatter of the next).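

In this assay, putting fluoro on the aromatic carbon para to a large group, which turns the 2-fluorophenyl into a 2,4-difluorophenyl, gives no change at the digits printed from compound 2 to compound 3 (within the scatter), so a second fluoro at this place brings out no inhibition. Replacing the 2-methoxyphenyl with the 2,4-difluorophenyl gives no change at the digits printed from compound 1 to compound 3 (within the scatter), so these two rings cannot be told apart on this read-out, and with no inhibition from any of the three compounds, it offers no way to rank them. No measurement at hand accounts for this flat result.

From the compounds shown here alone, whether an amine or a carboxylic acid on this same aromatic carbon would produce any inhibition remains open. The same holds for a longer chain at that place.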